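Swapping the aryl group on compound 2 before measurement

The source may hold more compounds than are shown below. What is called first, only, known or untested is meant among the compounds shown, and "the series" means these compounds.

Two compounds from this series have been run in a functional assay on DU-145 cells (Homo sapiens) for inhibition, read by MTT assay, with a stated time of 24 h; a higher number here means a weaker inhibitor, a lower number a stronger inhibitor. Within the data shown here, compound 1 `CCOC(=O)C1=Cc2ccccc2OC1(OCc1cn(CC(=O)NC2CCCCC2)nn1)C(F)(F)F` is the one with a full number: in this assay compound 1 gives 10200 nM. Compound 2 `CCOC(=O)C1=Cc2ccccc2OC1(OCc1cc(-c2ccc(OC)cc2)no1)C(F)(F)F` carries a 4-methoxyphenyl group on its five-membered aromatic ring with 1 nitrogen and 1 oxygen. In this assay compound 2 returns only a limit, > 150000 nM. Compound 2 thus sits at the limit of > 150000 nM in this assay, at which 1 of the 2 values shown sits, and where it stands is known only as not stronger than that limit. Among the measured compounds shown here, no step between measured compounds is available, since the two differ in more than one place.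

Compound 3 `CCOC(=O)C1=Cc2ccccc2OC1(OCc1cc(-c2cccc(C(F)(F)F)c2)no1)C(F)(F)F` has not yet been measured. It differs from compound 2 by 3-(trifluoromethyl)phenyl in place of 4-methoxyphenyl on an aromatic carbon. For the measured compounds named here, with no measured step to lean on, the expected step from compound 2 to compound 3 in this assay is an at least 1.2-fold lower number from compound 2 to compound 3 (0.09 log units; that floor lies within the scatter), which is to say nothing beyond the scatter. Compound 3 is expected to give about 120000 nM in this assay, within 30000 nM to 400000 nM, and a further limit-only result is judged more likely than not.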

Compound 3, half-maximal inhibitory concentration: 57300 nM
Compound 3: middle estimate off by 2.1-fold (0.32 log units), on the high side; low and high end bracket the measured number.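

In this assay, among these compounds, the aryl swap gives the first readable step, an at least 2.6-fold lower number from compound 2 to compound 3 (0.41 log units; beyond the scatter), which shows that the aryl group on this aromatic carbon, next to the ring nitrogen, bears on the read-out. The two earlier compounds could not show this, as they differ in more than one place. The true step may be larger than this floor, since the starting point of compound 2 is not a number but a limit: the limit of > 150000 nM in this assay, at which 1 of the 3 values shown sits.

Compound 3 returns a full number, 57300 nM, so a change to the aryl group alone is enough to give a measurable value at this position.

The two aryl groups differ both in their substituent and in where it is named on the phenyl ring, so this one pair cannot separate the effect of adding trifluoromethyl from that of losing methoxy or of the change in placement. From the compounds shown here alone, what a plain phenyl, a 4-(trifluoromethyl)phenyl or a 3-methoxyphenyl group would give at this carbon remains open.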